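The source may report more compounds than this note shows. Statements on the series, on what has been measured and on what is new or still open speak of the compounds shown alone.

Measured compounds:
- compound 1, `O=S(=O)(CSc1nnc(Br)n1Cc1ccc(Br)c2ccccc12)Nc1ccccc1`: 15800 nM
- compound 2, `O=S(=O)(CSc1nnc(Br)n1Cc1ccc(Br)c2ccccc12)Nc1cncc(C(F)(F)F)c1`: 6380 nM
- compound 3, `O=S(=O)(CSc1nnc(Br)n1Cc1ccc(Br)c2ccccc12)Nc1ccc(F)nc1`: 1550 nM

In an assay on HEK293 cells for inhibition of solute carrier family 22 member 12 (Homo sapiens) (on this read-out lower numbers stand for stronger inhibition and higher numbers for weaker inhibition), compound 2 stands second highest of the three numbers. Its nearest neighbour is compound 1, with a 2.5-fold lower number from compound 1 to compound 2 (0.39 log units; beyond the scatter); its furthest is compound 3, with a 4.1-fold lower number from compound 2 to compound 3 (0.61 log units; beyond the scatter). Compound 4, `O=S(=O)(CSc1nnc(Br)n1Cc1ccc(Br)c2ccccc12)Nc1ccc(Br)nc1`, has not yet been measured. It differs from compound 2 in one place: 6-bromopyridin-3-yl in place of 5-(trifluoromethyl)pyridin-3-yl on a sulfonamide nitrogen.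

Going by the values given here, two measured steps bear on this change. The step from compound 2 to compound 3 swapped the same trifluoromethyl-bearing ring for a 6-fluoropyridin-3-yl ring and gave a 4.1-fold lower number from compound 2 to compound 3 (0.61 log units; beyond the scatter). The step from compound 1 to compound 3 also ended at that fluorinated ring and gave a 10-fold lower number from compound 1 to compound 3 (1.01 log units; beyond the scatter). Among the compounds with values here, compound 4 carries bromine rather than fluorine at the same place on the pyridine, so no measured pair shows this exact exchange, but the pattern from compound 2 to compound 3 is the closest guide. A modest drop in number, in the direction of stronger inhibition, is therefore expected for compound 4, roughly matching a 3.2-fold lower number from compound 2 to compound 4 (0.50 log units; beyond the scatter). On that basis compound 4 is estimated at 2000 nM in this assay, within a range of 700 nM to 6000 nM.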

Compound 4, half-maximal inhibitory concentration: 2200 nM
Compound 4: middle estimate off by 1.1-fold (0.04 log units), on the low side; the measured number falls inside the stated range.
By their numbers in this assay, from the lowest: compounds 3 and 4 (each within the scatter of the next); then compound 2; then compound 1.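

In this assay the new result shows that the gain at the sulfonamide nitrogen does not belong to fluoro alone: bromo in place of fluoro on the pyridine ring gives a 1.4-fold higher number from compound 3 to compound 4 (0.15 log units; within the scatter) and so leaves the two halogens indistinguishable on this read-out. The 6-bromopyridin-3-yl group also keeps the advantage over the plain phenyl ring, with a 7.2-fold lower number from compound 1 to compound 4 (0.86 log units; beyond the scatter) as the step, and it beats the 5-(trifluoromethyl)pyridin-3-yl group, with a 2.9-fold lower number from compound 2 to compound 4 (0.46 log units; beyond the scatter) as the step, so both halogen-bearing pyridines now sit below compounds 1 and 2, and none of the four compounds goes against this. Nothing measured here explains why these changes act as they do.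

On these data alone, compounds 3 and 4 each differ from compound 1 by both a ring nitrogen and a halogen, so the share of each remains unknown, and a phenyl ring carrying bromo would be needed to separate them. As far as these compounds go, it also remains open whether the gain needs a halogen at all, or whether a methoxy or an amine at the same place on the pyridine would serve as well.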